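From 3-chlorophenyl to 3,4-dimethoxyphenyl: notes on the series

The compounds below may be only part of what the source reports. "The series", "measured", "known", "first", "only" and "open" are said of these compounds alone.

In a functional assay on DWD cells (Homo sapiens) for inhibition, read by sulforhodamine B assay (a higher number here means a weaker inhibitor of growth, a lower number a stronger inhibitor of growth), compound 1 (`Oc1cccc2[nH]c(-c3ccc(-c4ccc(-c5ccc(F)cc5)cc4)cc3)nc12`) gives 22200 nM, compound 2 (`Oc1ccc(-c2ccc(-c3ccc(-c4nc5c(O)cccc5[nH]4)cc3)cc2)cc1`) gives 2700 nM and compound 3 (`Oc1cccc2[nH]c(-c3ccc(-c4ccc(-c5cccc(Cl)c5)cc4)cc3)nc12`) gives 2100 nM. Compound 3 thus sits level with compound 2, well clear of compound 1.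

Compound 4 (`COc1ccc(-c2ccc(-c3ccc(-c4nc5c(O)cccc5[nH]4)cc3)cc2)cc1OC`) carries 3,4-dimethoxyphenyl in place of 3-chlorophenyl, on an aromatic carbon para to a large group: 3,4-dimethoxyphenyl in place of 3-chlorophenyl on an aromatic carbon.

Two swaps at this carbon bear on it: a 1.3-fold lower number from compound 2 to compound 3 (0.11 log units; within the scatter), and an 11-fold lower number from compound 1 to compound 3 (1.02 log units; beyond the scatter). The first suggests tolerance, and compound 1 is the exception. No step beyond the scatter is therefore expected, with a slight upward lean allowed for the risk shown by compound 1.

The expected step is a 1.4-fold higher number from compound 3 to compound 4 (0.15 log units; within the scatter). For compound 4 the estimate is 3000 nM, with an expected range of 1100 nM to 11000 nM.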

Compound 4, concentration for 50% growth inhibition: 1400 nM
Compound 4: the middle estimate sits 2.1-fold (0.33 log units) above what was measured; the measured number falls inside the stated range.
By their numbers in this assay, from the lowest: compounds 4, 3 and 2 (each within the scatter of the next); then compound 1.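

At this position, 3,4-dimethoxyphenyl is tolerated in this assay (a 1.5-fold lower number from compound 3 to compound 4 (0.18 log units; within the scatter); a 1.9-fold lower number from compound 2 to compound 4 (0.29 log units; within the scatter)), so the entry of hydrogen-bond acceptors leaves the number within the scatter of those for 3-chlorophenyl and 4-hydroxyphenyl. Against 4-fluorophenyl the gap stays wide (a 16-fold lower number from compound 1 to compound 4 (1.20 log units; beyond the scatter)), and compound 1 remains the only outlier among the four groups. No evidence is available on why these groups fall together or why compound 1 stands apart.

Open, as far as these compounds go, is whether 4-methoxyphenyl alone, or a phenyl ring bearing an amine or a carboxylic acid, stays in this range. Also open, from the compounds shown here alone, is whether 3-fluorophenyl would follow compound 1 or compound 3.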